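Series notes: 5-methylfuran-2-yl in place of 4-fluorophenyl

A few compounds are considered here, and "the series" means these few. Any claim that something is new, unique, unknown or untested is made for them only; others in the source may bear on it.

Of the compounds shown here, three on the shared core have been measured in a functional assay on aorta (strain Wistar) for inhibition, with Thoracic aorta (Rattus norvegicus) as the target; on this read-out higher numbers stand for weaker inhibition and lower numbers for stronger inhibition. Compound 1 `COc1nc(-c2cc3ccccc3o2)cc(-c2cccc3ccccc23)c1C#N` gives 359000 nM. Compound 2 `COc1nc(-c2cc3ccccc3o2)cc(-c2ccc(F)cc2)c1C#N` gives 321000 nM. Compound 3 `CCOc1nc(-c2cc3ccccc3o2)cc(-c2ccc(F)cc2)c1C#N` gives 396000 nM. Compound 2 stands at the low end of the three numbers, but neither compound 1 nor compound 3 is separable from it within the scatter. Among the measured compounds shown here, the only single-point step among the measured compounds, a 1.2-fold higher number from compound 2 to compound 3 (0.09 log units; within the scatter), concerns methyl in place of hydrogen on a saturated chain carbon bound to an oxygen on an aromatic ring and is within the scatter.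

Compound 4 `COc1nc(-c2cc3ccccc3o2)cc(-c2ccc(C)o2)c1C#N` differs from compound 2 by 5-methylfuran-2-yl in place of 4-fluorophenyl on an aromatic carbon. For the measured compounds named here, no measured step changes the group at this aromatic carbon, so the one step on record gives no guidance on size or direction; the series as a whole shows no movement beyond the scatter. Going by these compounds, the expectation for compound 4 in this assay is therefore no step beyond the scatter, a 1.0-fold higher number from compound 2 to compound 4 (0.01 log units; within the scatter), with a wide range because the change is untested. Compound 4 is estimated at 330000 nM, between 120000 nM and 900000 nM.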

Compound 4, half-maximal inhibitory concentration: 285000 nM
Compound 4: middle estimate off by 1.2-fold (0.06 log units), on the high side; low and high end bracket the measured number.
By their numbers in this assay, from the lowest: compounds 4, 2, 1 and 3 (each within the scatter of the next).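

Among the compounds shown here, at the aromatic carbon opposite the ring nitrogen, exchanging 4-fluorophenyl for 5-methylfuran-2-yl gives a 1.1-fold lower number from compound 2 to compound 4 (0.05 log units; within the scatter) in this assay and is the first change of group at this position. A six-membered aromatic ring of carbon only can therefore give way to a five-membered aromatic ring with 1 hetero atom and 1 hydrogen-bond acceptor without a step beyond the scatter. Nothing available bears on why this exchange leaves the read-out within the scatter.

The compounds shown leave open whether this position can move the read-out beyond the scatter at all, since only aromatic ring groups appear there. Going by these compounds, an amine or a carboxylic acid at this carbon would test that, and the effect of the same exchange with the ethoxy group of compound 3 also remains open.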